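The source may report more compounds than this note shows. Statements on the series, on what has been measured and on what is new or still open speak of the compounds shown alone.

Among the compounds with values here, in a functional assay (muscle tissue) with Cavia porcellus as the target (on this read-out higher numbers stand for an effect only at larger amounts of compound and lower numbers for an effect already at smaller amounts), compound 3 `COC(=O)C1=C(C)N=C(C)/C(=C(\O)OC)C1c1ccccc1F` gives 42.7 nM, the lowest of the three numbers so far. Compound 2 `COC(=O)C1=C(C)N=C(C)/C(=C(\O)OC)C1c1cc(Cl)cc(Cl)c1` gives 93.3 nM and compound 1 `COC(=O)C1=C(C)N=C(C)/C(=C(\O)OC)C1c1ccc(Cl)cc1` gives 8130 nM. Compound 4 `COC(=O)C1=C(C)N=C(C)/C(=C(\O)OC)C1c1cccc(Cl)c1Cl` is still unmeasured and carries one change from compound 3: 2,3-dichlorophenyl in place of 2-fluorophenyl on a saturated ring carbon. The large steps, an 87-fold lower number from compound 1 to compound 2 (1.94 log units; beyond the scatter) and a 190-fold lower number from compound 1 to compound 3 (2.28 log units; beyond the scatter), both leave 4-chlorophenyl, which compound 4 does not carry. The closest guide is the modest 2.2-fold lower number from compound 2 to compound 3 (0.34 log units; beyond the scatter). A small step is therefore expected in this assay, leaning slightly towards a lower number. The expected size is a 1.7-fold lower number from compound 3 to compound 4 (0.23 log units; within the scatter). The estimate for compound 4 is 25 nM, with an expected range of 4 nM to 150 nM.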

Compound 4, half-maximal effective concentration: 19.1 nM
Compound 4: middle estimate off by 1.3-fold (0.12 log units), on the high side, within the range that was stated.
By their numbers in this assay, from the lowest: compound 4; then compound 3; then compound 2; then compound 1.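

In this assay 2,3-dichlorophenyl on the saturated ring carbon gives a 2.2-fold lower number from compound 3 to compound 4 (0.35 log units; beyond the scatter) and also a 4.9-fold lower number from compound 2 to compound 4 (0.69 log units; beyond the scatter) and a 430-fold lower number from compound 1 to compound 4 (2.63 log units; beyond the scatter) with all three steps beyond the scatter. The step between the two dichlorophenyl compounds shows that this position responds to where the chlorines sit on the phenyl ring, not only to their presence. No measurement here bears on the reason for this order. Open, from the compounds shown here alone, is whether a nitro or methoxy group on the phenyl ring would follow the chlorine and fluorine compounds. Also open, going by these compounds, is whether this order holds in any other read-out.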